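Benzimidazole-to-amide linker swap in an orexin series

The source may report more compounds than this note shows. Statements on the series, on what has been measured and on what is new or still open speak of the compounds shown alone.

Two compounds of the series have numbers in an assay on CHO cells for displacement of a labelled ligand from Orexin/Hypocretin receptor type 1 (Homo sapiens); on this read-out lower numbers stand for stronger inhibition and higher numbers for weaker inhibition. Compound 1 `Cc1ccc2[nH]c(SCC(=O)N3CCC[C@H]3C(=O)Nc3ccccc3-n3cccc3)nc2c1` gives 3 nM and stands as the lowest of the two values. Compound 2 `Cn1c(CCC(=O)N2CCC[C@H]2C(=O)Nc2ccccc2-c2ccccc2)nc2ccccc21` gives 15 nM in this assay, a number clearly higher than that of compound 1, beyond the scatter. Compound 3 `O=C(Nc1ccccc1-n1cccc1)[C@@H]1CCCN1C(=O)CCc1nc2ccccc2[nH]1` has not yet been measured in this assay. It differs from compound 1 in one place: (1H-benzimidazol-2-yl)methyl in place of (5-methyl-1H-benzimidazol-2-yl)sulfanyl on a saturated chain carbon bound to a carbonyl carbon. For the measured compounds named here, no measured pair isolates this change, so its size can only be inferred. Compound 2, which carries a two-carbon chain between the benzimidazole and the carbonyl, gives 15 nM in this assay, which suggests that a carbon-linked benzimidazole is tolerated with some loss. The step from compound 1 to compound 3 is expected to be a modest weakening, about a 2.7-fold higher number from compound 1 to compound 3 (0.43 log units; beyond the scatter), roughly at the edge of the scatter. For compound 3 the expected value in this assay is 8 nM, with a range from 2.5 nM to 30 nM.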

Compound 3, inhibition constant: 130 nM
Estimate against measurement, compound 3: 16-fold (1.21 log units) below, and the stated range ends below it.
By their numbers in this assay, from the lowest: compound 1; then compound 2; then compound 3.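

In this assay the exchange of (5-methyl-1H-benzimidazol-2-yl)sulfanyl for (1H-benzimidazol-2-yl)methyl on a saturated chain carbon bound to a carbonyl carbon is a large step, a 43-fold higher number from compound 1 to compound 3 (1.64 log units; beyond the scatter), so the series is sensitive to this change at this position. The ring types and the hydrogen-bond donor count stay the same across the exchange, so a large loss accompanies a change that leaves both rings in place and removes the sulfur and the methyl. No measurement on hand explains this loss.

The step combines two edits, and the compounds shown do not separate the loss of the sulfur from the loss of the methyl. From the compounds shown here alone, it remains open whether an ether oxygen or an amine nitrogen in place of the sulfur, with the 5-methyl kept, would retain the standing of compound 1.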